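The source may hold more compounds than are shown below. What is called first, only, known or untested is meant among the compounds shown, and "the series" means these compounds.

Compounds measured in an assay on isolated protein for inhibition of Dihydrofolate reductase (Homo sapiens), read by spectrophotometry, using NADPH, with stated times of 5 s and 6 min; a higher number here means a weaker inhibitor, a lower number a stronger inhibitor:

Compound 1, `NC1=NC2(CCOCC2)N(OCCCOc2ccc(Cl)c(Cl)c2)C(N)=N1`, gives 8.23 nM.
Compound 2, `NC1=NC2(CCOCC2)N(OCCCOc2ccc(F)cc2)C(N)=N1`, gives 46.6 nM.
Compound 3, `NC1=NC2(CCOCC2)N(OCCCOc2cccc(Cl)c2Cl)C(N)=N1`, gives "not determined" (no result reported), so no result is reported for it in this assay.

Among the compounds with values here, the only step between measured compounds that differ in one place is a 5.7-fold higher number from compound 1 to compound 2 (0.75 log units; beyond the scatter), in which a 4-fluorophenyl replaces a 3,4-dichlorophenyl on an oxygen on a saturated carbon. Compound 3 itself stands nowhere on the numbers: no value in this assay is known for it, so the step to compound 4 has no measured starting point.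

Compound 4 is `NC1=NC2(CCOCC2)N(OCCCOc2ccc(Cl)cc2Cl)C(N)=N1`. It differs from compound 3 as follows: 2,4-dichlorophenyl in place of 2,3-dichlorophenyl on an oxygen on a saturated carbon. Within the data shown here, both compounds carry two chlorines on the phenyl ring, so neither is like the single fluorine of compound 2. The closest guide is compound 1, which also carries a dichlorophenyl on the oxygen and gives 8.23 nM, and the step of a 5.7-fold higher number from compound 1 to compound 2 (0.75 log units; beyond the scatter) shows how far a different substitution on that ring can move the value. Compound 4 is therefore expected to fall near the dichlorophenyl compound 1 rather than near compound 2, with an estimate in this assay of 15 nM, within a range of 4 nM to 60 nM.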

Compound 4, half-maximal inhibitory concentration: 7.46 nM
For compound 4 the middle estimate is 2.0-fold (0.30 log units) above the measured one; measured number inside the range.
By their numbers in this assay, from the lowest: compounds 4 and 1 (each within the scatter of the next); then compound 2.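

In this assay, the step of a 1.1-fold lower number from compound 1 to compound 4 (0.04 log units; within the scatter) shows that the 2,4-dichlorophenyl and 3,4-dichlorophenyl groups cannot be told apart at this place, on an oxygen on a saturated carbon. The step of a 6.2-fold lower number from compound 2 to compound 4 (0.80 log units; beyond the scatter) gives a second dichlorophenyl compound that stands apart from the 4-fluorophenyl compound 2, so the gap seen with compound 1 is not confined to a single chlorine arrangement. No measured evidence is available to explain why these groups compare as they do.

On these data alone, the step from compound 3 to compound 4 cannot be read, so it remains open whether the 2,3-dichlorophenyl group belongs with the other two dichlorophenyl groups. Also open, as far as these compounds go, is how a phenyl ring carrying an amine or a carboxylic acid, or a longer chain on the oxygen, would compare.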